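Swapping a benzyl arm for a tert-butylphenyl group

A few compounds are considered here, and "the series" means these few. Any claim that something is new, unique, unknown or untested is made for them only; others in the source may bear on it.

Of the compounds shown here, three sharing one core have been tested in a functional assay on MDA-MB-231 cells (Homo sapiens) for inhibition, read by CCK-8 assay, with a stated time of 48 h; a higher number here means a weaker inhibitor of growth, a lower number a stronger inhibitor of growth. Compound 1 `Cc1ccc(Nc2ncc(Cl)c(Nc3ccccc3C)n2)cc1` reaches only the limit of the assay, giving > 100000 nM. Compound 2 `Cc1ccccc1Nc1nc(Nc2cc(Cl)ccn2)ncc1Cl` gives 52400 nM in this assay, and the step of an at least 1.9-fold lower number from compound 1 to compound 2 (0.28 log units; that floor lies within the scatter) rests on a limit at one end. Compound 3 `COc1ccc(CNc2nc(Nc3ccc(N4CCN(C)CC4)cn3)ncc2Cl)cc1` gives 14900 nM in this assay, the lowest of the two numbers reported, and its gap to compound 2 lies beyond the scatter.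

Compound 4 `CN1CCN(c2ccc(Nc3ncc(Cl)c(Nc4ccc(C(C)(C)C)cc4)n3)nc2)CC1` has not yet been measured. It differs from compound 3 in one place: 4-(tert-butyl)phenyl in place of 4-methoxybenzyl on a nitrogen on an aromatic ring. For the measured compounds named here, none of the measured steps touches this position; the only step known, an at least 1.9-fold lower number from compound 1 to compound 2 (0.28 log units; that floor lies within the scatter), changes the other nitrogen on the core, so it gives no direct guide to what a change at this nitrogen does. Compound 1 carries an aryl group at the same nitrogen as compound 4, but its other arm differs as well, so the two cannot be compared directly.

Going by the values given here, with no step to lean on, he expects for compound 4 a number close to that of compound 3, a step of a 1.0-fold higher number from compound 3 to compound 4 (0.00 log units; within the scatter) that stays within the scatter, and estimates 15000 nM in this assay, with a range from 4000 nM to 60000 nM.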

Compound 4, concentration for 50% growth inhibition: 16200 nM
For compound 4 the middle estimate is 1.1-fold (0.03 log units) below the measured one; low and high end bracket the measured number.
By their numbers in this assay, from the lowest: compounds 3 and 4 (each within the scatter of the next); then compound 2. At a limit, above all of these: compound 1.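

In this assay, for the compounds shown here, the step of a 1.1-fold higher number from compound 3 to compound 4 (0.04 log units; within the scatter) gives the first direct reading at this nitrogen on the shared core, which none of the earlier compounds could provide. It shows that 4-methoxybenzyl can give way to 4-(tert-butyl)phenyl without a change that can be told from the scatter, even though the leaving group holds the one hydrogen-bond acceptor of the pair and the entering group holds none. The data offer no measurement that would explain why these two groups read alike at this position.

Both groups carry one six-membered aromatic ring of carbon only, so the compounds shown leave open what a group without such a ring, such as a plain methyl or a short chain ending in an amine or a carboxylic acid, would do on this nitrogen. Going by these compounds alone, they also leave open whether the same swap would read alike with a different group on the other nitrogen of the core, since the only pair that differs at this position is the one that carries the methylpiperazine arm.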